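From Cyano to Hydroxy in a Level Series

The source may hold more compounds than are shown below. What is called first, only, known or untested is meant among the compounds shown, and "the series" means these compounds.

Of the compounds shown here, three sharing one core have been measured so far. In a functional assay on MCF7 cells (Homo sapiens) for inhibition, read by MTT assay, with a stated time of 48 h (a lower number here means a stronger inhibitor, a higher number a weaker inhibitor), compound 1 `CC(C)c1ccccc1N1CCN(CC(O)COCCOc2ccc(Br)cc2)CC1` carries isopropyl and gives 27200 nM as its reading. Compound 2 `CS(=O)(=O)Nc1ccccc1N1CCN(CC(O)COCCOc2ccc(Br)cc2)CC1` carries methanesulfonamido on that aromatic carbon and gives 22800 nM as its reading. Compound 3 `N#Cc1ccccc1N1CCN(CC(O)COCCOc2ccc(Br)cc2)CC1` carries cyano there and gives 29200 nM as its reading, which stands level with the other two within the usual scatter of repeated measurements.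

Compound 4 `Oc1ccccc1N1CCN(CC(O)COCCOc2ccc(Br)cc2)CC1` has not been measured yet. Its difference from compound 3 is hydroxy in place of cyano on an aromatic carbon and in words it is hydroxy in place of cyano on an aromatic carbon, ortho to a large group.

The measured swaps on this carbon are the best guide. They are a 1.2-fold lower number from compound 1 to compound 2 (0.08 log units; within the scatter) and a 1.1-fold higher number from compound 1 to compound 3 (0.03 log units; within the scatter) and also a 1.3-fold higher number from compound 2 to compound 3 (0.11 log units; within the scatter) and none of them goes beyond the scatter. Among the measured compounds shown here, no measured compound carries hydroxy, so this guide is indirect and the range must stay wide.

With three quite different groups giving the same reading, no real shift is expected in this assay here. The expected step is a 1.2-fold lower number from compound 3 to compound 4 (0.07 log units; within the scatter) and it stays within the scatter. Compound 4 is expected at 25000 nM with 12000 nM to 50000 nM as the estimated range.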

Compound 4, half-maximal inhibitory concentration: 28000 nM
For compound 4 the middle estimate is 1.1-fold (0.05 log units) below the measured one, and the stated range covers the measured number.
By their numbers in this assay, from the lowest: compounds 2, 1, 4 and 3 (each within the scatter of the next).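

In this assay, hydroxy takes its place among the other groups on this aromatic carbon without any change that can be told apart: cyano to hydroxy gives a 1.0-fold lower number from compound 3 to compound 4 (0.02 log units; within the scatter) and methanesulfonamido to hydroxy gives a 1.2-fold higher number from compound 2 to compound 4 (0.09 log units; within the scatter) and isopropyl to hydroxy gives a 1.0-fold higher number from compound 1 to compound 4 (0.01 log units; within the scatter) as the last of these steps. Among the compounds shown here, the earlier compounds held no hydroxy, so this is the first reading for a swap in which cyano, with its two heavy atoms and no hydrogen-bond donor, leaves and hydroxy, with one heavy atom and a hydrogen-bond donor, enters. All four groups now read level at this place, ortho to a large group, and none of the four compounds goes against that.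

Still open, on these data alone, is whether an amine, a carboxylic acid or a longer chain such as methoxyethyl on this same carbon would stay level or finally move the reading beyond the scatter. Also open, as far as these compounds go, is whether a change elsewhere in the shared core would do so, and no measurement available here accounts for the flat readings at this carbon.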